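This account rests on a few compounds, and the source may have more. Where it says the series, first, only, none or still open, it means among the compounds named here.

Measured compounds:
compound 1 `CCCn1c(=O)[nH]c2nc(-c3ccc(S(=O)(=O)N4CCN(c5cccc(Cl)c5)CC4)cc3)[nH]c2c1=O` — > 1000 nM
compound 2 `CCCn1c(=O)[nH]c2nc(-c3ccc(S(=O)(=O)N4CCN(Cc5cccc(Br)c5)CC4)cc3)[nH]c2c1=O` — 928 nM
compound 3 `CCCn1c(=O)[nH]c2nc(-c3ccc(S(=O)(=O)N4CCN(C(C)c5ccccc5)CC4)cc3)[nH]c2c1=O` — >= 1000 nM

Compound 3 stands at a limit of the assay, not at a number. In an assay on CHO cells for displacement of a labelled ligand from adenosine receptor A1 (Homo sapiens), read by scintillation counting, with a stated time of 90 min, in the presence of a further agent that is not named here (on this read-out higher numbers stand for weaker inhibition and lower numbers for stronger inhibition), compound 3 gives >= 1000 nM (the limit of >= 1000 nM in this assay, at which 1 of the 3 values shown sits). Compound 1 likewise sits at a limit, (the limit of > 1000 nM in this assay, at which 1 of the 3 values shown sits). Compound 2 is the only one of the three with a number, and it lies close to those limits. The steps to compound 3 are an at least 1.0-fold higher number from compound 2 to compound 3 (0.03 log units; that floor lies within the scatter) and a step that the two limits leave unreadable from compound 1 to compound 3, so neither resolves anything beyond the scatter.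

Compound 4 `CCCn1c(=O)[nH]c2nc(-c3ccc(S(=O)(=O)N4CCN(Cc5ccc(Br)cc5)CC4)cc3)[nH]c2c1=O` carries 4-bromobenzyl in place of 1-phenylethyl on an amine nitrogen in a ring. The closest measured step is an at least 1.0-fold higher number from compound 2 to compound 3 (0.03 log units; that floor lies within the scatter); compound 4 reverses it, with the bromine moved to the 4-position of the benzyl ring. The step of an at least 1.0-fold lower number from compound 1 to compound 2 (0.03 log units; that floor lies within the scatter) is also within the scatter. Going by the values given here, no step reads beyond the scatter, so compound 4 is expected to land near compound 2, with the step estimated as an at least 1.1-fold lower number from compound 3 to compound 4 (0.04 log units; that floor lies within the scatter). Compound 4 is therefore estimated at 900 nM, within 350 nM to 3000 nM, with a real chance that the assay again reports only a limit.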

Compound 4, inhibition constant: > 1000 nM
Compound 4 gave a limit, no number; the forecaster's own chance of this, stated with the estimate: 40%; middle value at least 1.1-fold (0.04 log units) from the limit.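

Moving the bromine, 4-bromophenyl in place of 3-bromophenyl on a saturated chain carbon bound to an amine nitrogen in a ring, gives in this assay an at least 1.0-fold higher number from compound 2 to compound 4 (0.03 log units; that floor lies within the scatter), so this first comparison of two bromine positions on the benzyl group resolves no difference. The remaining steps to compound 4 cannot be read. Compound 4 gives a limit of the assay, not a number: the limit of > 1000 nM in this assay, at which 2 of the 4 values shown sit.

The compounds shown leave open whether any group on this ring nitrogen can give a value clearly apart from that of compound 2, for example a benzyl group carrying a carboxylic acid or a longer chain leading to the phenyl ring. Going by these compounds, how far compound 4 lies past its limit also stays open.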